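Aryl exchange from compound 3 to compound 4

A few compounds are considered here, and "the series" means these few. Any claim that something is new, unique, unknown or untested is made for them only; others in the source may bear on it.

In an ADME assay on Raji cells (Homo sapiens) for cytotoxicity, with a stated time of 72 h (a higher number here means that more compound is needed for the effect, a lower number that less compound is needed), compound 1 (`Cc1cc(NC(=O)Nc2ccccc2N)c2ccccc2n1`) reads > 25000 nM as a limit. Compound 2 (`COc1ccc(NC(=O)Nc2cc(C)nc3ccccc23)cc1Cl`) reads > 25000 nM as a limit. Compound 3 (`Cc1cc(NC(=O)Nc2ccccc2F)c2ccccc2n1`) reads > 25000 nM as a limit, so its standing is a limit and not a number. Going by the values given here, the picture for the series so far is the limit of > 25000 nM in this assay, at which 3 of the 3 values shown sit, and no compound has yet given a number.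

Compound 4 (`Cc1cc(NC(=O)Nc2cccc(Cl)c2)c2ccccc2n1`) carries 3-chlorophenyl in place of 2-fluorophenyl on an amide-type nitrogen. Among the compounds with values here, the one measured step bearing on this is a step that the two limits leave unreadable from compound 1 to compound 3 and it offers no size to carry over. The expectation therefore rests on compound 3 with its limit of > 25000 nM as the nearest reading, and no step beyond the scatter is expected in this assay in either direction. The expected step of a number no higher from compound 3 to compound 4 (the limit leaves the size open) is an estimate with no measured size behind it. For compound 4 the estimated value is 25000 nM with an expected range from 10000 nM to 40000 nM and a further limit is the likeliest report.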

Compound 4, half-maximal effective concentration: 18000 nM
The estimate for compound 4 lay 1.4-fold (0.14 log units) above the measured number; the measured number falls inside the stated range.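

In this assay compound 4, with 3-chlorophenyl on the amide-type nitrogen, is the only compound shown that gives a number (18000 nM). The 2-fluorophenyl and 2-aminophenyl groups at this place give only limits. The exchange reads as an at least 1.3-fold lower number from compound 3 to compound 4 (0.14 log units; that floor lies within the scatter) and, with 2-aminophenyl leaving, as an at least 1.3-fold lower number from compound 1 to compound 4 (0.14 log units; that floor lies within the scatter); hydrogen in place of methoxy reads as an at least 1.3-fold lower number from compound 2 to compound 4 (0.14 log units; that floor lies within the scatter) and thus links the number to the limit of the chlorinated, methoxy-bearing analogue. All three are floors rather than measured sizes, and the series still sits mainly at the limit: the limit of > 25000 nM in this assay, at which 3 of the 4 values shown sit.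

On these data alone, how a 3-fluorophenyl or a 2-chlorophenyl would read at this nitrogen stays open, so the identity of the halogen and its place on the ring cannot yet be separated. As far as these compounds go, the reading of an unsubstituted phenyl or a carboxylic acid on this ring is equally open.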